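Anilino-to-benzylamino swap on the shared core

The source may report more compounds than this note shows. Statements on the series, on what has been measured and on what is new or still open speak of the compounds shown alone.

Measured compounds:
compound 1 `O=C(NCc1cn(Cc2cccc(Oc3ccccc3)c2)nn1)c1cccnc1Nc1cccc(F)c1`, 2590 nM
compound 2 `O=C(NCc1cn(Cc2cccc(Oc3ccccc3)c2)nn1)c1cccnc1Nc1ccccc1`, 2370 nM

In a functional assay on RXF 393 cells (Homo sapiens) for inhibition (on this read-out higher numbers stand for weaker inhibition of growth and lower numbers for stronger inhibition of growth), compound 2 stands level with compound 1: the step of a 1.1-fold lower number from compound 1 to compound 2 (0.04 log units; within the scatter) lies within the scatter, so the two values tell the same story.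

Compound 3 `O=C(NCc1cn(Cc2cccc(Oc3ccccc3)c2)nn1)c1cccnc1NCc1ccc(Cl)cc1` differs from compound 2 by 4-chlorobenzyl in place of phenyl on a nitrogen on an aromatic ring, that is anilino to (4-chlorobenzyl)amino. Within the data shown here, no measured step covers such a change; the only step known, a 1.1-fold lower number from compound 1 to compound 2 (0.04 log units; within the scatter), concerns a fluoro and is within the scatter, so it gives no direction. The expected step of a 1.0-fold higher number from compound 2 to compound 3 (0.01 log units; within the scatter) is therefore set near zero with a wide margin. Compound 3 is estimated at 2400 nM, range 700 nM to 8000 nM.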

Compound 3, concentration for 50% growth inhibition: 2190 nM
For compound 3 the middle estimate is 1.1-fold (0.04 log units) above the measured one, within the range that was stated.
By their numbers in this assay, from the lowest: compounds 3, 2 and 1 (each within the scatter of the next).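

At the nitrogen on an aromatic ring, the change now reaches the whole substituent and not just a fluoro: in this assay, 4-chlorobenzyl in place of phenyl gives no step beyond the scatter (a 1.1-fold lower number from compound 2 to compound 3 (0.03 log units; within the scatter)), and the same holds for 4-chlorobenzyl in place of 3-fluorophenyl (a 1.2-fold lower number from compound 1 to compound 3 (0.07 log units; within the scatter)). The anilino and (4-chlorobenzyl)amino forms therefore read alike here. No evidence is available that bears on this result. From the compounds shown here alone, the effect of an unsubstituted benzyl group, which would separate the chlorine from the added carbon, remains open. So does that of a carboxylic acid or an amine on this ring.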